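Varying the Amine on a Long-Chain Carbamate Scaffold

The compounds below may be only part of what the source reports. "The series", "measured", "known", "first", "only" and "open" are said of these compounds alone.

Measured compounds:
compound 1, `CCCCCCCCCCCCCC[C@H](OCOC)[C@H](CN(CC)CC)NC(=O)OC(C)(C)C`: 25.3%
compound 2, `CCCCCCCCCCCCCC[C@H](OCOC)[C@H](CN(C(C)C)C(C)C)NC(=O)OC(C)(C)C`: 26.9%

Both compounds were tested in a functional assay on MCF7 cells (Homo sapiens) for antiproliferative activity, read by sulforhodamine B assay, with a stated time of 48 h, tested at 10 uM; a higher number here means more inhibition at the concentration tested (going by the name of the read-out), a lower number less inhibition. Compound 2 stands at 26.9%, and compound 1 sits nearby, since the step of a number 1.6 percentage points higher from compound 1 to compound 2 (within the scatter) is within the scatter. So swapping one amine for another has, so far, left the read-out essentially unchanged.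

Compound 3, `CCCCCCCCCCCCCC[C@H](OCOC)[C@H](CN(CCCC)CCCC)NC(=O)OC(C)(C)C`, is the next step in the same direction. Compared with compound 2, the change is dibutylamino in place of diisopropylamino on a saturated chain carbon, two bonds along the chain from an amide-type nitrogen. Within the data shown here, the only step that bears on it is the one from compound 1 to compound 2, which was a number 1.6 percentage points higher from compound 1 to compound 2 (within the scatter), a change too small to count. With no other guide, compound 3 is expected to behave like the two measured compounds, so the step is estimated as a number 0.1 percentage points higher from compound 2 to compound 3 (within the scatter), that is, no shift beyond the scatter. Compound 3 is therefore estimated at 27%, with a likely range from 12% to 42%.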

Compound 3, a percentage reported as inhibition, at one concentration (the size of the read-out at that concentration, not a potency): 27.1%
Estimate against measurement, compound 3: 0.1 percentage points below; the range from low to high includes it.
By their numbers in this assay, from the lowest: compounds 1, 2 and 3 (each within the scatter of the next).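

In this assay, dibutylamino in place of diisopropylamino gives a number 0.2 percentage points higher from compound 2 to compound 3 (within the scatter) and dibutylamino in place of diethylamino gives a number 1.8 percentage points higher from compound 1 to compound 3 (within the scatter). Among these compounds, this position, on a saturated chain carbon, two bonds along the chain from an amide-type nitrogen, has now carried three different dialkylamino groups with no step beyond the scatter, which the single earlier step could not show. No outside information is available to explain this flat result.

As far as these compounds go, whether an amine with a ring, such as piperidine or morpholine, or a primary amine at this position would move the number remains open. Also open, from the compounds shown here alone, is whether changing the long chain or the carbamate on the shared core, rather than the amine, would shift the read-out.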